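The compounds below may be only part of what the source reports. "The series", "measured", "known", "first", "only" and "open" are said of these compounds alone.

Of the compounds shown here, three have so far been measured in a functional assay on HEK293 cells for agonist activity at Free fatty acid receptor 1 (Homo sapiens), read by HTRF and inositol phosphate accumulation, with a stated time of 60 min; a lower number here means that less compound is needed, a higher number that more compound is needed for the effect. Compound 1 `O=C(O)CC[C@H]1CCc2cc(-c3cc(OC4CCC4)cc(F)c3F)ccc2O1` gives only the limit of the assay, > 10000 nM. Compound 2 `Fc1ccc(OC(F)(F)F)cc1-c1ccc2c(c1)CC[C@H](CCc1nnn[nH]1)O2` likewise gives only a limit, > 10000 nM. Compound 3 `CO[C@H]1C[C@H](Oc2cc(F)c(F)c(-c3ccc4c(c3)CC[C@H](CCc3nnn[nH]3)O4)c2)C1` also gives a limit, > 10000 nM. Compound 1 thus stands at the limit of > 10000 nM in this assay, at which 3 of the 3 values shown sit, together with the other two measured compounds, so none of the three shows a measurable potency. Compound 4 `O=C(O)CC[C@H]1CCc2cc(-c3cc(OC4CCC4)ccc3F)ccc2O1` has not yet been measured. It differs from compound 1 in one place: hydrogen in place of fluoro on an aromatic carbon. Among the compounds with values here, every measured value sits at the limit, so no step between measured compounds is available to guide the expectation. A step no larger than the usual scatter, or none at all, is expected for a number no higher from compound 1 to compound 4 (the limit leaves the size open). Compound 4 is therefore estimated at 10000 nM, most likely once more reported as a limit, within the range 3000 nM to 30000 nM.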

Compound 4, half-maximal effective concentration: 3600 nM
Compound 4: the middle estimate sits 2.8-fold (0.44 log units) above what was measured; low and high end bracket the measured number.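

In this assay, hydrogen in place of fluoro on this aromatic carbon, ortho to a fluoro group and meta to a cyclobutyloxy group, gives an at least 2.7-fold lower number from compound 1 to compound 4 (0.44 log units; beyond the scatter). This single atom change is enough to bring the series to a measurable number, and this position therefore matters for the read-out. Compound 4 is the only compound shown with a number, and the others remain at a limit: the limit of > 10000 nM in this assay, at which 3 of the 4 values shown sit.

From the compounds shown here alone, whether a chloro or a methoxy group on this carbon would give a lower or higher number stays open. So does whether the same change would have a similar effect in compounds with a different group in place of the cyclobutyloxy group.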